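Chloro to benzylamino: expectation for compound 4

A few compounds are considered here, and "the series" means these few. Any claim that something is new, unique, unknown or untested is made for them only; others in the source may bear on it.

Among the measured compounds shown here, compound 3 `Cc1noc(NS(=O)(=O)c2cccc3c(Cl)cccc23)c1C` gives 24000 nM in an assay on VSM-A10 cells for antagonist activity at Endothelin-1 receptor (Rattus norvegicus) (a higher number here means a weaker inhibitor, a lower number a stronger inhibitor), the highest of the three numbers measured so far. Compound 1 `CCCCCNc1cccc2c(S(=O)(=O)Nc3onc(C)c3C)cccc12` gives 80 nM in this assay, and compound 2 `Cc1noc(NS(=O)(=O)c2cccc3c(NCCCCCc4ccccc4)cccc23)c1C` gives 3050 nM. The step of a 300-fold higher number from compound 1 to compound 3 (2.48 log units; beyond the scatter) shows what chloro costs against pentylamino, and the step of a 38-fold higher number from compound 1 to compound 2 (1.58 log units; beyond the scatter) shows the cost of phenyl in place of hydrogen on a saturated chain carbon, five bonds along the chain from a nitrogen on an aromatic ring.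

Compound 4 `Cc1noc(NS(=O)(=O)c2cccc3c(NCc4ccccc4)cccc23)c1C` differs from compound 3 in one place: benzylamino in place of chloro on an aromatic carbon. Both measured steps bear on it. Restoring an amino substituent in place of chloro is the reverse of the large loss seen for compound 3, while attaching a phenyl to the chain was costly in the step of a 38-fold higher number from compound 1 to compound 2 (1.58 log units; beyond the scatter). Benzylamino combines both features on a shorter chain than either compound 1 or compound 2 carries. The expected step of a 16-fold lower number from compound 3 to compound 4 (1.20 log units; beyond the scatter) is therefore downward in this assay, large but short of what pentylamino achieved. Compound 4 is estimated at 1500 nM, with a range from 300 nM to 8000 nM.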

Compound 4, half-maximal inhibitory concentration: 590 nM
Compound 4: middle estimate off by 2.5-fold (0.41 log units), on the high side; low and high end bracket the measured number.
By their numbers in this assay, from the lowest: compound 1; then compound 4; then compound 2; then compound 3.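

In this assay, an amino-linked group on this aromatic carbon recovers much of what chloro gives up, even when it carries a phenyl ring: a 41-fold lower number from compound 3 to compound 4 (1.61 log units; beyond the scatter). Chain length matters for the phenyl-bearing groups, with a 5.2-fold lower number from compound 2 to compound 4 (0.71 log units; beyond the scatter) as the chain shortens to benzylamino, yet pentylamino stays ahead of benzylamino, with a 7.4-fold higher number from compound 1 to compound 4 (0.87 log units; beyond the scatter). Nothing available accounts for these steps.

On these data alone, whether the amine hydrogen is needed remains open, and a dimethylamino group or a pentyloxy chain on this aromatic carbon would address it. As far as these compounds go, it is also open where a phenethylamino or propylamino group would fall relative to the benzylamino and pentylamino groups.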